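A few compounds are considered here, and "the series" means these few. Any claim that something is new, unique, unknown or untested is made for them only; others in the source may bear on it.

Three compounds share one core. Compound 1 `O=C(CN1CCC(c2cccc[n+]2[O-])CC1)Nc1cccc(Cl)c1` gives 62 nM in a functional assay on HEK293 cells for agonist activity at D(4) dopamine receptor (Homo sapiens), read by FLIPR; a higher number here means that more compound is needed for the effect, a lower number that less compound is needed. Compound 2 `Cc1cc(C)cc(NC(=O)CN2CCC(c3cccc[n+]3[O-])CC2)c1` gives 52 nM in this assay; the step of a 1.2-fold lower number from compound 1 to compound 2 (0.08 log units; within the scatter) swapped one aryl group for another on an amide-type nitrogen and stayed within the scatter. Compound 3 `Cc1cc(C(=O)NCN2CCC(c3cccc[n+]3[O-])CC2)ccc1F` gives 50 nM in this assay, the lowest of the three numbers, yet within the scatter of both compound 2 and compound 1. Compound 4 `N#Cc1cccc(C(=O)NCN2CCC(c3cccc[n+]3[O-])CC2)c1` has not yet been measured; it differs from compound 3 by 3-cyanophenyl in place of 4-fluoro-3-methylphenyl on a carbonyl carbon. Within the data shown here, the only measured step is an aryl swap at another place, and it was within the scatter. Compound 4 is therefore expected to show a step of a 1.2-fold higher number from compound 3 to compound 4 (0.08 log units; within the scatter) within the scatter, with an estimated value of 60 nM, ranging from 25 nM to 150 nM.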

Compound 4, half-maximal effective concentration: 840 nM
Beside the measured number, compound 4's estimate is 14-fold (1.15 log units) below it; the whole stated range lies below it.
By their numbers in this assay, from the lowest: compounds 3, 2 and 1 (each within the scatter of the next); then compound 4.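

At this place on a carbonyl carbon, the aryl group cannot be swapped freely: in this assay, 3-cyanophenyl in place of 4-fluoro-3-methylphenyl gives a 17-fold higher number from compound 3 to compound 4 (1.23 log units; beyond the scatter) and is the first step beyond the scatter among these compounds. The earlier aryl swap on an amide-type nitrogen, a 1.2-fold lower number from compound 1 to compound 2 (0.08 log units; within the scatter) stayed within the scatter, and that tolerance did not carry over to this position. Nothing available bears on why the number rose.

Because the change removes the fluorine and methyl and adds the nitrile at once, the compounds shown cannot say which part matters. Phenyl, 4-fluorophenyl, 3-methylphenyl or 4-cyanophenyl at this place remain open.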